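Swapping a methyl on the sulfonyl-bearing aromatic ring

A few compounds are considered here, and "the series" means these few. Any claim that something is new, unique, unknown or untested is made for them only; others in the source may bear on it.

Compound 1 `Cc1ccc(C)c(S(=O)(=O)N(C)/N=C/c2cnn3ccc(C#N)cc23)c1` gives 2100 nM
Compound 2 `CN(/N=C/c1cnn2ccc(C#N)cc12)C(=O)c1cccc([N+](=O)[O-])c1` gives 1800 nM

In a functional assay on NZB5 cells (Homo sapiens) for inhibition, read by thymidine incorporation, with a stated time of 5 days (on this read-out higher numbers stand for weaker inhibition and lower numbers for stronger inhibition), compound 1 gives 2100 nM and compound 2 gives 1800 nM, two values within the scatter of each other. Compound 1 therefore cannot be set apart from compound 2 on these numbers. Compound 3 `Cc1ccc(NC(=O)C(F)(F)F)cc1S(=O)(=O)N(C)/N=C/c1cnn2ccc(C#N)cc12` keeps the core of compound 1 but carries ((trifluoromethyl)carbonyl)amino in place of methyl on an aromatic carbon of a six-membered aromatic ring of carbon only, meta to a large group and para to a methyl group (((trifluoromethyl)carbonyl)amino in place of methyl on an aromatic carbon). Among the measured compounds shown here, no measured pair differs in one place only, so the data give no direct guide to this change. In this assay no step beyond the scatter is expected, and the estimated step of a 1.4-fold lower number from compound 1 to compound 3 (0.15 log units; within the scatter) has no firm direction. For compound 3 the estimated value is 1500 nM, with an expected range of 400 nM to 6000 nM.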

Compound 3, half-maximal inhibitory concentration: 2300 nM
Beside the measured number, compound 3's estimate is 1.5-fold (0.19 log units) below it; the range from low to high includes it.
By their numbers in this assay, from the lowest: compounds 2, 1 and 3 (each within the scatter of the next).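

In this assay, putting ((trifluoromethyl)carbonyl)amino in place of methyl on an aromatic carbon gives a 1.1-fold higher number from compound 1 to compound 3 (0.04 log units; within the scatter). Among the compounds shown here, this is the first direct comparison at this position, and it shows that a far larger group, bringing a hydrogen-bond donor and a hydrogen-bond acceptor, leaves the number within the scatter of that of the small methyl. Nothing on hand accounts for this result.

The compounds shown leave open whether a free amine, an acetylamino group or a longer acyl chain at this place would also give a number within the scatter. For the compounds shown here, they also leave open whether the trifluoromethyl or the amide hydrogen has any bearing on the number, since no compound here carries one without the other.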